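Adding a Single Methyl to a Macrocyclic Polyphenol

This account rests on a few compounds, and the source may have more. Where it says the series, first, only, none or still open, it means among the compounds named here.

Three compounds have been looked at in a functional assay on PC-3 cells (Homo sapiens) for antiproliferative activity, read by MTT assay, with a stated time of 48 h; on this read-out lower numbers stand for stronger inhibition and higher numbers for weaker inhibition:
compound 1 `Oc1ccc2c(c1)CCc1ccc(O)c(c1)Oc1ccc(cc1)CCc1cccc(O)c1O2` gives "not determined" (no result reported);
compound 2 `Oc1cc2c(cc1O)Oc1c(O)cccc1CCc1ccc(cc1)Oc1cc(ccc1O)CC2` gives 7700 nM;
compound 3 `Oc1ccc2c(c1)CCc1ccc(O)c(c1)Oc1ccc(cc1O)CCc1cccc(O)c1O2` gives "not determined" (no result reported).

Within the data shown here, of these, compound 2 is the only one with a number attached. Among the measured compounds shown here, compounds 1 and 3 carry no result, so no step between measured compounds can be drawn, and nothing yet shows how any structural change moves the read-out. Compound 2 therefore stands alone as the sole point of reference, a weak-to-moderate inhibitor of cell growth at the concentration recorded above.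

Compound 4 `COc1cccc2c1Oc1cc(O)c(O)cc1CCc1ccc(O)c(c1)Oc1ccc(cc1)CC2` has not been measured. It differs from compound 2 in one place: methyl in place of hydrogen on an oxygen on an aromatic ring. For the measured compounds named here, a change confined to one position would usually be expected to move the read-out only a little, and with no step between measured compounds to lean on, the expectation is a step no larger than the scatter of repeat measurements, if anything toward weaker inhibition. Because compound 2 gives 7700 nM in this assay, compound 4 is expected to give 9500 nM, within a range of 4000 nM to 25000 nM. The step is thus estimated as a 1.2-fold higher number from compound 2 to compound 4 (0.09 log units; within the scatter).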

Compound 4, half-maximal inhibitory concentration: 5510 nM
Estimate against measurement, compound 4: 1.7-fold (0.24 log units) above; the range from low to high includes it.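

Among these compounds, this is the first step that can be read, and it concerns a single place: a hydroxy group on an aromatic ring becomes a methoxy group, with methyl taking the place of the hydrogen on the oxygen. In this assay, this change gives a 1.4-fold lower number from compound 2 to compound 4 (0.15 log units; within the scatter), so the two compounds cannot be told apart on this read-out, and this hydrogen can be replaced by a methyl group without a step beyond the scatter. That is a statement about this one oxygen and this one small group only, and no independent measurement is available here to explain why the read-out holds steady.

The compounds shown leave open whether a larger group on the same oxygen, such as a longer chain like butyl or a chain ending in a carboxylic acid or an amine, would also leave the read-out within the scatter. They also leave open whether methyl on any of the other hydroxy groups of the shared core would give a similarly small step, since this single pair speaks for one position alone.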